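The source may hold more compounds than are shown below. What is called first, only, known or untested is meant among the compounds shown, and "the series" means these compounds.

The measured compounds:

Compound 1, `COc1ccc(-c2cc3ccccc3nc2/C=C/C(=O)c2ccc(F)cc2)cc1`, gives 820 nM in a functional assay on NCI-H1299 cells (Homo sapiens) for antiproliferative activity, read by XTT assay, with a stated time of 72 h; on this read-out lower numbers stand for stronger inhibition and higher numbers for weaker inhibition.
Compound 2, `COc1ccc(-c2cc3ccccc3nc2/C=C/C(=O)c2ccsc2)cc1`, gives 1220 nM.

In this series only these two numbers are available, and compound 2 carries the higher of them. The gap to compound 1, a 1.5-fold higher number from compound 1 to compound 2 (0.17 log units; within the scatter), is small enough that the two compounds cannot be separated in this assay. Compound 3, `COc1ccc(-c2cc3ccccc3nc2/C=C/C(=O)c2c[nH]c3ccccc23)cc1`, has not yet been measured. It keeps the shared core of compound 2 and differs from it in one place: 1H-indol-3-yl in place of thiophen-3-yl on a carbonyl carbon. Among the compounds with values here, the only measured step that speaks to this change is the one from compound 1 to compound 2, where the group on the carbonyl carbon was swapped and the number barely moved. On that evidence the account expects the new swap also to leave the result within the scatter, with no direction favoured; the indol-3-yl group is larger than thiophen-3-yl, but nothing measured here says how that will register. The estimate for compound 3 is therefore 1100 nM, with a range from 400 nM to 3000 nM, which means an expected step of a 1.1-fold lower number from compound 2 to compound 3 (0.04 log units; within the scatter).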

Compound 3, half-maximal inhibitory concentration: > 10000 nM
Compound 3 gave a limit, no number (the forecaster's own chance of this, stated with the estimate: 5%); middle value at least 9.0-fold (0.95 log units) from the limit.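

In this assay, compound 3 reads > 10000 nM, which is a limit of the assay and not a number: the limit of > 10000 nM in this assay, at which 1 of the 3 values shown sits.

Putting 1H-indol-3-yl in place of thiophen-3-yl on the carbonyl carbon gives an at least 8.1-fold higher number from compound 2 to compound 3 (0.91 log units; beyond the scatter), and putting it in place of 4-fluorophenyl gives an at least 12-fold higher number from compound 1 to compound 3 (1.08 log units; beyond the scatter). The group on this carbonyl carbon is therefore not freely exchangeable, as the single swap between compound 1 and compound 2 had left it looking: among the groups shown, only 1H-indol-3-yl, which brings a six-membered aromatic ring of carbon only and a hydrogen-bond donor, produces a change beyond the scatter.

The compounds shown do not tell whether the added ring or the hydrogen-bond donor goes with this loss, a question on which a benzothiophen-3-yl or a 1-methylindol-3-yl group on the carbonyl carbon would bear. From the compounds shown here alone, how far compound 3 lies past its limit also stays open, and with it the true size of both steps.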